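This account rests on a few compounds, and the source may have more. Where it says the series, first, only, none or still open, it means among the compounds named here.

Working notes on the series, read in a functional assay on U-937 cells (Homo sapiens) for inhibition, read by MTT assay, with a stated time of 24 h; on this read-out higher numbers stand for weaker inhibition of growth and lower numbers for stronger inhibition of growth. Compound 1 (`Cc1cn(-c2cc(C(=O)Nc3cccc(C4=Nc5cnn(Cc6ccccc6)c5NC(=O)C4)c3)cc(C(F)(F)F)c2)cn1`) gives > 30000 nM, which is a limit of the assay and not a number. Compound 2 (`O=C1CC(c2ccc(NC(=O)Nc3ccc(Cl)c(C(F)(F)F)c3)cc2)=Nc2cn[nH]c2N1`) gives > 30000 nM, which is likewise a limit. For the measured compounds named here, compound 3 (`COc1ccc(Cn2ncc3c2NC(=O)CC(c2cccc(NC(=O)Nc4cc(Cl)cc(Cl)c4)c2)=N3)cc1`) gives 6480 nM, the only true number so far in this assay. Compound 1 and compound 2 thus mark (the limit of > 30000 nM in this assay, at which 2 of the 3 values shown sit).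

The next compound to be read is compound 4 (`COc1ccc(Cn2ncc3c2NC(=O)CC(c2cccc(NC(=O)Nc4ccc(C(F)(F)F)cc4)c2)=N3)cc1`). It keeps the core of compound 3 and changes one group: 4-(trifluoromethyl)phenyl in place of 3,5-dichlorophenyl on an amide-type nitrogen. In words, 4-(trifluoromethyl)phenyl stands in place of 3,5-dichlorophenyl on an amide-type nitrogen.

Going by the values given here, no measured pair isolates this change, so the expected size of the step rests on little. Among the compounds with values here, with compound 3 at 6480 nM as the only number, a modest move toward weaker growth inhibition in this assay is expected, though it may not clear the usual scatter by much. The estimated change is a 1.7-fold higher number from compound 3 to compound 4 (0.23 log units; within the scatter). A reading that reaches only the assay limit remains possible. The expected value for compound 4 is 11000 nM, with an estimated range of 3500 nM to 30000 nM.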

Compound 4, concentration for 50% growth inhibition: 110 nM
For compound 4 the middle estimate is 100-fold (2.00 log units) above the measured one; the measured number lies below the stated range.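

In this assay, 4-(trifluoromethyl)phenyl in place of 3,5-dichlorophenyl on an amide-type nitrogen gives a 59-fold lower number from compound 3 to compound 4 (1.77 log units; beyond the scatter). For the compounds shown here, with the rest of compound 3 held fixed, this place on the series proves highly sensitive to the group it carries, and this is the first step that can be read at all, since the other readings without a true number sit at a limit: the limit of > 30000 nM in this assay, at which 2 of the 4 values shown sit. The sensitivity does not show up in the simple counts, as the two groups match in aromatic ring type, hydrogen-bond donors, hydrogen-bond acceptors and net charge, and differ in heavy atoms and in the halogen they carry.

This single pair changes the halogen, the group attached to the ring and the substitution pattern all at once, so the data cannot assign the step in this assay to any one of these. From the compounds shown here alone, how 4-chlorophenyl or 3-(trifluoromethyl)phenyl would read at this place remains open, as does whether 4-(trifluoromethyl)phenyl keeps its effect when the 4-methoxybenzyl group of compound 4 gives way to another group.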